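The source may hold more compounds than are shown below. What is called first, only, known or untested is meant among the compounds shown, and "the series" means these compounds.

Measured so far in a functional assay on BGC-823 cells (Homo sapiens) for cytotoxicity, read by MTT assay, with a stated time of 48 h; on this read-out higher numbers stand for weaker inhibition and lower numbers for stronger inhibition:
compound 1 `C=CCOc1ccc2c(NCCCN(C)C)ccnc2c1` gives 6680 nM;
compound 2 `CN(C)CCNc1ccnc2cc(OCc3ccc(F)cc3)ccc12` gives 890 nM;
compound 3 `Fc1ccc(COc2ccc3c(Cl)ccnc3c2)cc1` gives 2780 nM.

Compound 2 has the lowest number of the three; compound 3 is nearest and compound 1 furthest, both beyond the scatter.

Compound 4 `C=CCOc1ccc2c(NCCN(C)C)ccnc2c1` is not yet measured. It differs from compound 2 in one place: vinyl in place of 4-fluorophenyl on a saturated chain carbon bound to an oxygen on an aromatic ring.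

Among the compounds with values here, the only measured single-point step, a 3.1-fold higher number from compound 2 to compound 3 (0.49 log units; beyond the scatter), changes the amino group on the aromatic carbon, not the group on the ether oxygen, so it does not bear on this change. Compound 1 carries the allyl ether but also a longer amine chain, so its gap to compound 2 cannot be split between the two changes; all that can be said is that compound 1 and compound 2 differ beyond the scatter, with the allyl ether on the higher number. Some rise is therefore expected in this assay, of uncertain size, and compound 4 is expected to land between compound 2 and compound 1. For compound 4 the expected step is a 3.9-fold higher number from compound 2 to compound 4 (0.59 log units; beyond the scatter). The expected value for compound 4 is 3500 nM, in the range 1300 nM to 10000 nM.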

Compound 4, half-maximal inhibitory concentration: 1360 nM
Estimate against measurement, compound 4: 2.6-fold (0.41 log units) above; the measured number falls inside the stated range.
By their numbers in this assay, from the lowest: compounds 2 and 4 (each within the scatter of the next); then compound 3; then compound 1.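

In this assay, the change from 4-fluorobenzyl to allyl on the ether oxygen gives a 1.5-fold higher number from compound 2 to compound 4 (0.18 log units; within the scatter), so at this position the 4-fluorophenyl ring, with its 7 heavy atoms, can give way to vinyl with no change that can be read. The amine chain does register: dimethylamino in place of (dimethylamino)methyl, with the allyl ether held constant, gives a 4.9-fold lower number from compound 1 to compound 4 (0.69 log units; beyond the scatter), a step that compound 1 alone could not separate from the ether group. No measurement at hand gives a reason for either step.

Open, going by these compounds, is whether a plain methyl or an unsubstituted benzyl on the ether oxygen would also stay within the scatter of compound 2 and compound 4. Also open, on these data alone, is whether the longer amine chain gives a similar step when the 4-fluorobenzyl ether is present.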